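The source may hold more compounds than are shown below. What is called first, only, known or untested is meant among the compounds shown, and "the series" means these compounds.

Among the measured compounds shown here, in a functional assay on ileum for inhibition of histamine H1 receptor (Cavia porcellus) (a higher number here means a weaker inhibitor, a lower number a stronger inhibitor), compound 1 `CCCN1CCCN(c2nc3ccccc3n2CCOCC)CC1` gives 8.4 nM, the lower of the two numbers known so far; compound 2 `CCNCCn1c(N2CCN(C)CC2)nc2ccccc21` gives 290 nM, a number beyond the scatter above that of compound 1. Compound 3 `CCCCN1CCCN(c2nc3ccccc3n2CCOCC)CC1` differs from compound 1 in one place: methyl in place of hydrogen on a saturated chain carbon, three bonds along the chain from an amine nitrogen in a ring, which, cut one bond further out, reads propyl to butyl. For the measured compounds named here, no measured pair shows this change, so its size is open. A lengthening of the chain by one carbon is expected to move this assay little, if at all, beyond the scatter: the expected step is a 1.1-fold lower number from compound 1 to compound 3 (0.02 log units; within the scatter). Compound 3 is therefore estimated at 8 nM, within 3 nM to 25 nM.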

Compound 3, half-maximal inhibitory concentration: 8.4 nM
For compound 3 the middle estimate is 1.1-fold (0.02 log units) below the measured one, and the stated range covers the measured number.
By their numbers in this assay, from the lowest: compounds 1 and 3 (each within the scatter of the next); then compound 2.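

Methyl in place of hydrogen on a saturated chain carbon, three bonds along the chain from an amine nitrogen in a ring, gives no change at the digits printed from compound 1 to compound 3 (within the scatter) in this assay. Among the compounds shown here, this is the first measured step at this position, and it shows that butyl serves as well as propyl here. No supporting data bear on why the number holds at this position.

Going by these compounds, whether a longer chain such as hexyl keeps the number stays open. So does the effect of a carboxylic acid or an amine at the end of this chain.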